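This account rests on a few compounds, and the source may have more. Where it says the series, first, only, none or still open, it means among the compounds named here.

Measured so far, in a functional assay on the whole organism for agonist activity, with Mus musculus as the target; a lower number here means that less compound is needed, a higher number that more compound is needed for the effect:
Compound 1 `COC(=O)N(C)C(C)C#CCN1CCCC1` gives 9.7 mg/kg.
Compound 2 `COC(=O)N(C)C(C)C#CCn1ccnc1` gives 6.6 mg/kg.
Compound 3 `CN(C)C(=O)N(C)CC#CCN1CCCC1` gives 1.2 mg/kg.

Compound 3 holds the lowest number of the three; its steps to compound 2 and to compound 1 are both beyond the scatter. The difference between the core of compound 3 and the core of compound 1 is not broken down here. Between compound 1 and compound 2 one change is made, (1H-imidazol-1-yl in place of pyrrolidin-1-yl on a saturated chain carbon bound to a triple-bonded carbon), and it gave a 1.5-fold lower number from compound 1 to compound 2 (0.17 log units; within the scatter). Compound 4 `CN(C)C(=O)N(C)CC#CCn1ccnc1` is not yet measured; it carries the same change on the core of compound 3: 1H-imidazol-1-yl in place of pyrrolidin-1-yl on a saturated chain carbon bound to a triple-bonded carbon. The change occurs twice among these compounds, and its only measured instance is the step from compound 1 to compound 2. The step from compound 3 to compound 4 is therefore expected to be small, a 1.3-fold lower number from compound 3 to compound 4 (0.12 log units; within the scatter), because a 1.5-fold lower number from compound 1 to compound 2 (0.17 log units; within the scatter) stayed within the scatter. Compound 4 is expected to give about 0.9 mg/kg in this assay, with a range of 0.4 mg/kg to 2.5 mg/kg.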

Compound 4, dose for half-maximal effect: 11.8 mg/kg
Beside the measured number, compound 4's estimate is 13-fold (1.12 log units) below it, outside the stated range (above it).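

In this assay, 1H-imidazol-1-yl in place of pyrrolidin-1-yl gives a 9.8-fold higher number from compound 3 to compound 4 (0.99 log units; beyond the scatter), and the change does not act alike on the two cores: the same change on two cores in this assay, a 1.5-fold lower number (0.17 log units; within the scatter) from compound 1 to compound 2 and a 9.8-fold higher number (0.99 log units; beyond the scatter) from compound 3 to compound 4, 14-fold (1.16 log units) apart, beyond the scatter of two such steps. Within the data shown here, the small step on the core of compound 1 is therefore no guide to the step on the core of compound 3, and the change cannot be carried from one core to the other as a fixed shift. The comparison rests on a single pair of cores whose difference is not broken down, so it does not show which part of the core goes with the larger step, why the two steps differ, or how the change would behave on any further core.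

Going by these compounds, it remains open whether another group on a saturated chain carbon bound to a triple-bonded carbon, such as piperidin-1-yl or dimethylamino, would follow pyrrolidin-1-yl or 1H-imidazol-1-yl on each core. On these data alone, a longer chain in that place is equally open.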